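This account rests on a few compounds, and the source may have more. Where it says the series, first, only, none or still open, it means among the compounds named here.

Measured compounds in the series:

compound 1, `COC(=O)c1c(Nc2ccc(OC)cc2)sc(C(=O)c2ccc(OC)cc2)c1C`: 7.8%
compound 2, `COc1ccc(C(=O)c2sc(Nc3ccccc3)c(C(=O)O)c2C)cc1`: 36.5%
compound 3, `COc1ccc(C(=O)c2sc(Nc3ccc(C)cc3)c(C(=O)O)c2C)cc1`: "not active" (no number reported)

Compound 3 stands without a number in a functional assay, with a stated time of 150 min, tested at 15 ug/mL; on this read-out lower numbers stand for a weaker effect and higher numbers for a stronger effect at the one concentration tested: the read-out was reported as not active, so no value can be set beside compound 2 or compound 1, and nothing can be said of how far it lies from either. Compound 2 gives 36.5% and compound 1 gives 7.8% in this assay, which marks out the range the measured members of the series have covered so far.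

Compound 4, `COc1ccc(Nc2sc(C(=O)c3ccc(OC)cc3)c(C)c2C(=O)O)cc1`, is to be measured in this assay. It differs from compound 3 in one place: methoxy in place of methyl on an aromatic carbon. The methyl leaves and a methoxy enters on an aromatic carbon of a six-membered aromatic ring of carbon only, so that the (4-methylphenyl)amino of compound 3 becomes the (4-methoxyphenyl)amino of compound 4.

For the measured compounds named here, no measured pair shows this change, and compound 3 itself carries no number, so no step can be computed. Any change in this assay is expected to be small, at most a modest rise from the inactive reading of compound 3, and a result within the scatter of that inactive reading is as likely. Compound 4 is expected to give about 10%, in the range 0% to 30%, because compound 1, which carries the same methoxy on that ring, gives 7.8%.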

Compound 4, a percentage reported as activity, at one concentration (the size of the read-out at that concentration, not a potency): 30.6%
The estimate for compound 4 lay 20.6 percentage points below the measured number; measured number above the stated range.
By their numbers in this assay, from the lowest: compound 1; then compounds 4 and 2 (each within the scatter of the next).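

In this assay the methoxy on the aromatic ring of the (4-methoxyphenyl)amino group reads level with hydrogen at that place (a number 5.9 percentage points lower from compound 2 to compound 4 (within the scatter)), so with the carboxylic acid present this change makes no difference beyond the scatter. With that methoxy held fixed, the methyl ester and the carboxylic acid do separate (a number 22.8 percentage points higher from compound 1 to compound 4 (beyond the scatter)), the first sign that hydrogen in place of methyl on that oxygen matters more in this series than methoxy in place of hydrogen on the ring. The step between the 4-methylphenyl of compound 3 and the 4-methoxyphenyl of compound 4 cannot be read, as compound 3 has only a "not active" report and no number.

Still open, as far as these compounds go, is how a chloro group, a hydroxy group or an amine at the same place on that ring would read, and whether an amide could stand in for the carboxylic acid. No measurement at hand accounts for these numbers.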